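The source may hold more compounds than are shown below. What is called first, only, known or untested is meant among the compounds shown, and "the series" means these compounds.

Compound 1 `COc1cc(-c2nnc(SCC(=O)c3ccc(C(F)(F)F)cc3)n2N)cc(OC)c1OC` gives > 100000 nM in a functional assay on HepG2 cells (Homo sapiens) for antiproliferative activity, read by MTT assay, with a stated time of 48 h (on this read-out higher numbers stand for weaker inhibition and lower numbers for stronger inhibition), which is a limit of the assay rather than a number.
Compound 2 `COc1cc(-c2nnc(SCC(=O)Nc3ccc(C)cc3)n2N)cc(OC)c1OC` gives > 100000 nM in this assay, again a limit.
Compound 3 `COc1cccc(NC(=O)CSc2nnc(-c3cc(OC)c(OC)c(OC)c3)n2N)c1` gives > 100000 nM in this assay, also a limit.

Compound 1 therefore stands only at a limit, as do the two further values. Compound 4 `COc1cc(-c2nnc(SCC(=O)NCc3ccc(C)cc3)n2N)cc(OC)c1OC` differs from compound 1 in one place: (4-methylbenzyl)amino in place of 4-(trifluoromethyl)phenyl on a carbonyl carbon. Going by the values given here, the steps that bear on this change, a step that the two limits leave unreadable from compound 1 to compound 2 and a step that the two limits leave unreadable from compound 1 to compound 3, both swap the same group on the carbonyl carbon for an arylamino group, yet neither can be read because of the limit of > 100000 nM in this assay, at which 3 of the 3 values shown sit. Among the compounds with values here, no step of readable size or direction can be expected, and it seems most likely that compound 4 will again sit at the limit. Compound 4 is estimated at 150000 nM, within 50000 nM to 500000 nM, which is expected to mean a step that the limit leaves unreadable from compound 1 to compound 4.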

Compound 4, half-maximal inhibitory concentration: > 100000 nM
Compound 4: no number, only a limit; the forecaster's own chance of this, stated with the estimate: 85%; the middle value does not contradict the limit.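

No step can be read between compound 4 and compound 1, compound 2 or compound 3, because all four compounds stand at the same limit rather than at a number: the limit of > 100000 nM in this assay, at which 4 of the 4 values shown sit.

The compounds shown leave open whether any group on the carbonyl carbon gives a measurable value in this assay.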